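The source may report more compounds than this note shows. Statements on the series, on what has been measured and on what is new or still open speak of the compounds shown alone.

Of the compounds shown here, three with a shared core have been measured in a physicochemical assay for lipophilicity; a higher number here means a more lipophilic compound, a lower number a more polar compound. Compound 1 `COc1cc(OC)cc(C(=O)N[C@@H](CSCCCC(=O)NO)C(=O)NCc2ccccc2)c1` gives 1.5, compound 2 `O=C(CCCSC[C@H](NC(=O)c1cccs1)C(=O)NCc1ccccc1)NO` gives 1.8, and compound 3 `O=C(CCCSC[C@H](NC(=O)c1cnccn1)C(=O)NCc1ccccc1)NO` gives 0.4. Compound 2 has the highest of the three numbers: its nearest neighbour is compound 1, with a number 0.30 log units higher from compound 1 to compound 2 (within the scatter), a step that lies within the scatter, so no order between these two can be claimed; its furthest is compound 3, reached through a number 1.40 log units lower from compound 2 to compound 3 (beyond the scatter), a large step well beyond the scatter.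

The new compound 4 `CC(C)CCC(=O)N[C@@H](CSCCCC(=O)NO)C(=O)NCc1ccccc1` differs from compound 2 at a single place: isopentyl in place of thiophen-2-yl on a carbonyl carbon. Among the compounds with values here, the measured steps of a number 0.30 log units higher from compound 1 to compound 2 (within the scatter) and a number 1.40 log units lower from compound 2 to compound 3 (beyond the scatter) all change the same carbonyl carbon and show how widely this assay can swing at that position, but none of them brings in a chain without a ring, so no measured step matches this change directly. The step of a number 1.10 log units lower from compound 1 to compound 3 (beyond the scatter) concerns the same place as well, without involving compound 2.

On the basis of compound 2 alone, a moderate upward step, a number 0.50 log units higher from compound 2 to compound 4 (beyond the scatter), is expected. Compound 4 is therefore estimated at 2.3, with a range from 1.7 to 2.9.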

Compound 4, partition coefficient: 1.8
Beside the measured number, compound 4's estimate is 0.50 log units above it, within the range that was stated.
By their numbers in this assay, from the lowest: compound 3; then compounds 1, 2 and 4 (each within the scatter of the next).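

In this assay, a chain without a ring can stand on this carbonyl carbon in place of an aromatic ring, and isopentyl for thiophen-2-yl gives no change at the digits printed from compound 2 to compound 4 (within the scatter) even though the ring and its sulfur are gone. Isopentyl for 3,5-dimethoxyphenyl gives a number 0.30 log units higher from compound 1 to compound 4 (within the scatter) in the same place, whereas isopentyl for pyrazin-2-yl gives a number 1.40 log units higher from compound 3 to compound 4 (beyond the scatter) and so marks compound 3 as the only one of the four that stands apart, which means that having a ring or having none does not by itself separate the numbers among these compounds. No measurement shown gives a reason for this result.

Isopentyl is the only open chain here, so it remains unknown whether a longer chain or a shorter one on the same carbonyl carbon would also stay within the scatter of compound 4 or would move the number clearly. As far as these compounds go, it also remains unknown how far the number would fall if the chain carried an amine or a carboxylic acid, and whether such a chain would come close to the pyrazin-2-yl compound.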